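Aryl substituent series: projecting compound 4

The source may hold more compounds than are shown below. What is called first, only, known or untested is meant among the compounds shown, and "the series" means these compounds.

Measured so far:
compound 1, `Clc1ccc(N2N=NCC2c2ccncc2)cc1`, gives 43.5 mg/kg in a functional assay on the whole organism with Mus musculus as the target; a higher number here means that more compound is needed for the effect, a lower number that less compound is needed
compound 2, `c1ccc(N2N=NCC2c2ccncc2)cc1`, gives 107 mg/kg in this assay
compound 3, `Fc1ccc(N2N=NCC2c2ccncc2)cc1`, gives 203 mg/kg in this assay

Compound 3 stands highest of the three numbers in this assay. The step of a 1.9-fold higher number from compound 2 to compound 3 (0.28 log units; within the scatter) is within the scatter, so compound 2 and compound 3 cannot be ordered on these data. The step of a 4.7-fold higher number from compound 1 to compound 3 (0.67 log units; beyond the scatter) is beyond the scatter, as is a 2.5-fold higher number from compound 1 to compound 2 (0.39 log units; beyond the scatter); compound 1, with chloro on the aromatic carbon, has the lowest number of the set.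

Compound 4, `FC(F)(F)c1ccc(N2N=NCC2c2ccncc2)cc1`, differs from compound 3 by trifluoromethyl in place of fluoro on an aromatic carbon. Among the measured compounds shown here, no measured step involves a trifluoromethyl group; the only exchanges at this aromatic carbon are among chloro, hydrogen and fluoro, and only the steps away from the chloro compound exceed the scatter. The basis for any projection is therefore thin. Compound 4 is estimated at 80 mg/kg, with a range from 30 mg/kg to 220 mg/kg. This estimate corresponds to an expected step of a 2.5-fold lower number from compound 3 to compound 4 (0.40 log units; beyond the scatter), toward a lower number, but the range is wide enough to include no change beyond the scatter.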

Compound 4, dose for half-maximal effect: 421 mg/kg
Beside the measured number, compound 4's estimate is 5.3-fold (0.72 log units) below it; measured number outside the range, above it.
By their numbers in this assay, from the lowest: compound 1; then compounds 2 and 3 (each within the scatter of the next); then compound 4.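

Trifluoromethyl on this aromatic carbon gives a 2.1-fold higher number from compound 3 to compound 4 (0.32 log units; beyond the scatter), so a step away from fluoro now exceeds the scatter in this assay. Against hydrogen the change is a 3.9-fold higher number from compound 2 to compound 4 (0.59 log units; beyond the scatter), which runs opposite to the chloro-hydrogen exchange, a 2.5-fold higher number from compound 1 to compound 2 (0.39 log units; beyond the scatter): this is the first group shown to raise the number beyond the scatter relative to hydrogen, and chloro and trifluoromethyl lie on opposite sides of it. The widest span at this carbon is now a 9.7-fold higher number from compound 1 to compound 4 (0.99 log units; beyond the scatter), and compound 4 carries the highest number, with its steps to all three other compounds beyond the scatter.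

No available evidence bears on what separates chloro from trifluoromethyl at this carbon. As far as these compounds go, how a methoxy group, a nitrile or an amine at the same carbon would place in this order remains open.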